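Swapping trifluoromethyl for hydroxy on a weak anilide core

A few compounds are considered here, and "the series" means these few. Any claim that something is new, unique, unknown or untested is made for them only; others in the source may bear on it.

All three measured compounds share one core and differ in what hangs from the anilide ring and from the ring nitrogen. Compound 1, `O=C(Nc1ccc(O)cc1)C1NCCc2ccccc21`, gives 4370 nM in a functional assay on NUGC-3 cells (Homo sapiens) for inhibition, read by sulforhodamine B assay, with a stated time of 48 h; a higher number here means a weaker inhibitor of growth, a lower number a stronger inhibitor of growth. Compound 2, `O=C(Nc1cccc(C(F)(F)F)c1)C1c2ccccc2CCN1C(=O)c1ccc(Cl)cc1`, reaches only the limit > 10000 nM in this assay, so only a limit and no number is known for it. Compound 3, `O=C(Nc1cccc(C(F)(F)F)c1)C1NCCc2ccccc21`, likewise sits at the limit > 10000 nM. The step from compound 2 to compound 3, a step that the two limits leave unreadable from compound 2 to compound 3, cannot be read, and the standing of compound 2 is therefore set only by the limit of > 10000 nM in this assay, at which 2 of the 3 values shown sit.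

Compound 4, `O=C(Nc1cccc(O)c1)C1c2ccccc2CCN1C(=O)c1ccc(Cl)cc1`, is not yet measured. It differs from compound 2 by hydroxy in place of trifluoromethyl on an aromatic carbon. Among the compounds with values here, no measured step follows this change, so none can be used to size it. What can be said is that compound 1 carries a hydroxy group and gives a number, while compound 3 carries trifluoromethyl and sits at a limit; the two also differ in where the group sits and in what the ring nitrogen bears, so they do not isolate the change.

Compound 4 is therefore expected to land near the limit, with an estimated value of 9000 nM and a range from 2500 nM to 30000 nM, meaning an expected step of an at least 1.1-fold lower number from compound 2 to compound 4 (0.04 log units; that floor lies within the scatter).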

Compound 4, concentration for 50% growth inhibition: > 10000 nM
Compound 4: no number, only a limit; the forecaster's own chance of this, stated with the estimate: 50%; at least 1.1-fold (0.04 log units) between middle value and limit.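

Compound 2 and compound 4 both stop at a limit rather than a number in this assay, so the change from trifluoromethyl to hydroxy gives no readable step: the limit of > 10000 nM in this assay, at which 3 of the 4 values shown sit.

The compounds shown leave open what true values compound 2 and compound 4 have, and whether this swap alters growth inhibition at all.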